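The compounds below may be only part of what the source reports. "The series", "measured", "known", "first", "only" and "open" are said of these compounds alone.

Compounds measured in a functional assay on the whole organism (strain Swiss) with Mus musculus as the target, in the maximal electroshock model, with a stated time of 0.25 h, at a dose of 100 mg/kg by the intraperitoneal route; a higher number here means a stronger effect of the compound at the dose given, a lower number a weaker effect:

compound 1, `CC(C(=O)N1CCN(c2cccc(Cl)c2)CC1)N1C(=O)CCC1=O` — 50%
compound 2, `CC(C(=O)N1CCN(c2ccc(Cl)cc2)CC1)N1C(=O)CCC1=O` — 50%
compound 3, `CC(C(=O)N1CCN(c2ccccc2F)CC1)N1C(=O)CCC1=O` — 75%

Compound 3 holds the highest of the three numbers in this assay. Its nearest neighbour is compound 1, which lies a number 25 percentage points higher from compound 1 to compound 3 (beyond the scatter), and the same gap separates it from compound 2, a number 25 percentage points higher from compound 2 to compound 3 (beyond the scatter). Between compound 1 and compound 2 there is no change at the digits printed from compound 1 to compound 2 (within the scatter), so the two chlorophenyl compounds sit together and only compound 3 stands apart.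

Compound 4, `Cc1cccc(N2CCN(C(=O)C(C)N3C(=O)CCC3=O)CC2)c1`, has not yet been measured in this assay. It differs from compound 3 at one place:

3-methylphenyl in place of 2-fluorophenyl on an amine nitrogen in a ring

Among the compounds with values here, no measured step exchanges a 2-fluorophenyl for a 3-methylphenyl, so no step bears on it directly. What is known is that both chlorophenyl compounds, compound 1 and compound 2, give the same lower number, and the 2-fluorophenyl of compound 3 the higher one. Because compound 1, which also carries its group at the 3-position of the phenyl ring, gives 50%, compound 4 is expected to fall back toward that level, a step of a number 25 percentage points lower from compound 3 to compound 4 (beyond the scatter). For compound 4 the estimate in this assay is 50%, with a range from 25% to 75%.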

Compound 4, a percentage reported as activity, at one dose (the size of the read-out at that dose, not a potency): 0%
Beside the measured number, compound 4's estimate is 50 percentage points above it; measured number outside the range, below it.
By their numbers in this assay, from the lowest: compound 4; then compounds 1 and 2 (each within the scatter of the next); then compound 3.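

In this assay, methyl in place of chloro on an aromatic carbon brings a number 50 percentage points lower from compound 1 to compound 4 (beyond the scatter), so the group at this place on the phenyl ring can matter even where the two chlorophenyl compounds gave no difference. The 3-methylphenyl also falls well short of the other two groups, with a number 50 percentage points lower from compound 2 to compound 4 (beyond the scatter) and a number 75 percentage points lower from compound 3 to compound 4 (beyond the scatter). Among these four compounds, moving chloro left the number unchanged, whereas this exchange of chloro for methyl takes it down to the 0% of compound 4.

Nothing given here explains this drop. The compounds shown also leave open whether a 2-methylphenyl or a 3-fluorophenyl would stay near compound 3 or near compound 4, since compound 3 and compound 4 differ in both the group and its place on the phenyl ring.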